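Paw edema inhibition across four related triazole thioacetamides

The source may report more compounds than this note shows. Statements on the series, on what has been measured and on what is new or still open speak of the compounds shown alone.

Measured compounds:
Compound 1, `C=CCn1c(SCC(=O)Nc2ccc(/C(C)=N/O)cc2)nnc1-c1ccccc1`: 73%
Compound 2, `C/C(=N\O)c1ccc(NC(=O)CSc2nnc(-c3ccccc3)n2-c2ccccc2)cc1`: 67%
Compound 3, `CCn1c(SCC(=O)Nc2ccc(/C(C)=N/O)cc2)nnc1-c1ccc(OC)cc1`: 73%

In a functional assay on the whole organism (strain albino) for inhibition, with Rattus norvegicus as the target, read by paw edema, with stated times of 30 min and 4 h, at a dose of 0.28 mmol/kg by the oral route (on this read-out lower numbers stand for less inhibition and higher numbers for more inhibition at the one dose given (going by the name of the read-out)), compound 2 stands lowest of the three numbers, yet the gaps to compound 1 and to compound 3 are both within the usual scatter, so the three compounds cannot be told apart on these data. Among the measured compounds shown here, the one step with a single change is a number 6 percentage points lower from compound 1 to compound 2 (within the scatter), a change that does not touch the place altered here. Compound 4, `COc1ccc(-c2nnc(SCC(=O)Nc3ccc(/C(C)=N/O)cc3)n2-c2ccccc2)cc1OC`, differs from compound 2 in one place: 3,4-dimethoxyphenyl in place of phenyl on an aromatic carbon. For the measured compounds named here, no measured pair isolates this change. Compound 3 carries a methoxy-bearing aryl group at the same ring carbon and an ethyl group on the ring nitrogen, and its value sits within the scatter of compound 2, so the values at hand give no hint of a shift beyond the scatter in either direction. The step from compound 2 to compound 4 is therefore expected to be small, a number 2 percentage points higher from compound 2 to compound 4 (within the scatter), with no direction claimed beyond the scatter. Compound 4 is estimated at 69%, with a range from 56% to 80%.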

Compound 4, a percentage reported as inhibition, in the whole organism at one dose (the size of the read-out at that dose, not a potency): 79%
Beside the measured number, compound 4's estimate is 10 percentage points below it; the measured number falls inside the stated range.
By their numbers in this assay, from the lowest: compounds 2, 1, 3 and 4 (each within the scatter of the next, the first and the last beyond it).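

In this assay, putting 3,4-dimethoxyphenyl in place of phenyl on the aromatic carbon between two ring nitrogen atoms gives a number 12 percentage points higher from compound 2 to compound 4 (beyond the scatter). Among the compounds shown here, the only earlier single change, made on the ring nitrogen, gave a number 6 percentage points lower from compound 1 to compound 2 (within the scatter), so this ring carbon is the first place where one change moves the number past the usual scatter of the read-out. No measurement shown here explains the step, and it cannot be said whether the larger size of the entering group, its two oxygen atoms or something else lies behind it.

What the compounds leave open is whether both methoxy groups are needed, since a single methoxy group on the phenyl ring is never tested alone against the same ring nitrogen substituent, and compound 3 differs from compound 4 in more than one place. Also open, from the compounds shown here alone, is how the number would respond at this ring carbon to a group of a different kind, such as a chlorophenyl, a small methyl, or a phenyl bearing an amine or a carboxylic acid.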